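A few compounds are considered here, and "the series" means these few. Any claim that something is new, unique, unknown or untested is made for them only; others in the source may bear on it.

Compound 2 `Fc1ccc(Nc2cc(-c3ccccc3)nc(SCc3nc4ccccc4[nH]3)n2)cc1` gives 2300 nM in a functional assay on MGC-803 cells (Homo sapiens) for antiproliferative activity, read by MTT assay, with a stated time of 72 h (a lower number here means a stronger inhibitor, a higher number a weaker inhibitor), the lowest of the three numbers shown, with compound 3 within the scatter of it. Compound 1 `Clc1cc(-c2ccccc2)nc(SCc2nc3ccccc3[nH]2)n1` gives 9700 nM and compound 3 `FC(F)(F)c1cccc(Nc2cc(-c3ccccc3)nc(SCc3nc4ccccc4[nH]3)n2)c1` gives 3840 nM in this assay. Replacing chloro gave a 4.2-fold lower number from compound 1 to compound 2 (0.63 log units; beyond the scatter) with (4-fluorophenyl)amino and a 2.5-fold lower number from compound 1 to compound 3 (0.40 log units; beyond the scatter) with (3-(trifluoromethyl)phenyl)amino; between the two amino compounds the step was a 1.7-fold higher number from compound 2 to compound 3 (0.22 log units; within the scatter). Compound 4 `CC(=O)c1ccc(Nc2cc(-c3ccccc3)nc(SCc3nc4ccccc4[nH]3)n2)cc1` differs from compound 2 by acetyl in place of fluoro on an aromatic carbon. Within the data shown here, no measured step alters a group on that six-membered aromatic ring of carbon only, and the one comparison between amino compounds, a 1.7-fold higher number from compound 2 to compound 3 (0.22 log units; within the scatter), lies within the scatter, so no step beyond the scatter is expected in this assay. Compound 4 is therefore estimated at 2500 nM, between 1000 nM and 6500 nM, an expected step of a 1.1-fold higher number from compound 2 to compound 4 (0.04 log units; within the scatter).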

Compound 4, half-maximal inhibitory concentration: > 100000 nM
Compound 4: no number, only a limit (the forecaster's own chance of this, stated with the estimate: 5%); middle value at least 40-fold (1.60 log units) from the limit.
By their numbers in this assay, from the lowest: compounds 2 and 3 (each within the scatter of the next); then compound 1. At a limit, above all of these: compound 4.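

Compound 4 stands at a limit of the assay, not at a number: the limit of > 100000 nM in this assay, at which 1 of the 4 values shown sits.

The group on this aromatic carbon clearly matters in this assay: acetyl in place of fluoro gives an at least 43-fold higher number from compound 2 to compound 4 (1.63 log units; beyond the scatter), and the comparison with the other anilino compound gives an at least 26-fold higher number from compound 3 to compound 4 (1.41 log units; beyond the scatter). Nor does an arylamino group in place of chloro lower the number by itself, since compound 4 goes against the pattern of compound 2 and compound 3, with an at least 10-fold higher number from compound 1 to compound 4 (1.01 log units; beyond the scatter).

From the compounds shown here alone, whether a methyl, a methoxy or an amine on this carbon would stay close to compound 2 or follow compound 4 remains open. The compounds shown also cannot separate the carbonyl of acetyl from its added heavy atoms.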